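The compounds below may be only part of what the source reports. "The series", "measured", "known", "first", "only" and "open" are said of these compounds alone.

Measured so far in an assay on membranes from CHO cells for displacement of a labelled ligand from adenosine receptor A1 (Homo sapiens), read by scintillation counting, with a stated time of 60 min, tested at 1 uM; a lower number here means less inhibition, a higher number more inhibition at the concentration tested (going by the name of the read-out):
- compound 1, `CCCOC(=O)C1=C(C)NC(=O)NC1c1cccs1`: 43%
- compound 2, `CC1=C(C(=O)OCC(C)C)C(c2cccs2)NC(=O)N1`: 25%
- compound 3, `CC1=C(C(=O)NC(C)C)C(c2cccs2)NC(=O)N1`: 2%

Compound 3 stands lowest of the three. The step from the ester of compound 1 to the amide of compound 3 is a number 41 percentage points lower from compound 1 to compound 3 (beyond the scatter), and the corresponding step from compound 2 is a number 23 percentage points lower from compound 2 to compound 3 (beyond the scatter); both are beyond the scatter. Between the two esters the step is a number 18 percentage points lower from compound 1 to compound 2 (beyond the scatter).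

Compound 4, `CCSC(=O)C1=C(C)NC(=O)NC1c1cccs1`, has not yet been measured. It differs from compound 3 in one place: ethylsulfanyl in place of isopropylamino on a carbonyl carbon. The two steps that bear on this are the ones leading into compound 3, because a number 41 percentage points lower from compound 1 to compound 3 (beyond the scatter) and a number 23 percentage points lower from compound 2 to compound 3 (beyond the scatter) both show that replacing an ester-type group on that carbonyl carbon with isopropylamino lowered inhibition. The change to compound 4 removes the isopropylamino group again, so an increase in the same assay is the expectation rather than a drop, though the ethylsulfanyl group is not one of the groups already measured, and how far the number recovers is uncertain.

The estimated step from compound 3 to compound 4 in this assay is a number 30 percentage points higher from compound 3 to compound 4 (beyond the scatter). For compound 4 the expected value is 32%, with a likely range from 10% to 55%.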

Compound 4, a percentage reported as inhibition, at one concentration (the size of the read-out at that concentration, not a potency): 6%
Compound 4: middle estimate off by 26 percentage points, on the high side, outside the stated range (below it).
By their numbers in this assay, from the lowest: compounds 3 and 4 (each within the scatter of the next); then compound 2; then compound 1.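

In this assay, putting ethylsulfanyl in place of isopropylamino on this carbonyl carbon gives no readable change, with a number 4 percentage points higher from compound 3 to compound 4 (within the scatter). Compound 4 has no amide hydrogen, so removing the isopropylamino group and its hydrogen-bond donor is not enough on its own to return the number to the level of the two esters: the step from isobutoxy is a number 19 percentage points lower from compound 2 to compound 4 (beyond the scatter) and the step from propoxy is a number 37 percentage points lower from compound 1 to compound 4 (beyond the scatter). Among these four compounds, only the two with an oxygen-linked chain on the carbonyl carbon stand clear of compound 3, but no measurement here explains why.

Going by these compounds, both steps from the esters change the linking atom and the chain together, so the share of each in the lower numbers remains open. Ethoxy and propylsulfanyl groups on the same carbonyl carbon would help separate the two, by pairing the ethyl chain with oxygen and the propyl chain with sulfur.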